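A Nitrile on the Benzyl Ring: Forecast for Compound 4

The compounds below may be only part of what the source reports. "The series", "measured", "known", "first", "only" and "open" are said of these compounds alone.

Compound 1, `Cc1ccc(Cn2cc(COc3ccc4c(=O)ccoc4c3)nn2)cc1`, gives 68500 nM in a functional assay on QGY7701 cells (Homo sapiens) for cytotoxicity, read by MTT assay, with a stated time of 48 h; a higher number here means a weaker inhibitor, a lower number a stronger inhibitor.
Compound 2, `O=c1ccoc2cc(OCc3cn(Cc4cccc(Br)c4)nn3)ccc12`, gives 17600 nM.
Compound 3, `O=c1ccoc2cc(OCc3cn(Cc4ccccc4)nn3)ccc12`, gives > 100000 nM.

The value for compound 3 is a limit of the assay, not a number: compound 3 stands at the limit of > 100000 nM in this assay, at which 1 of the 3 values shown sits. Compound 4, `N#Cc1cccc(Cn2cc(COc3ccc4c(=O)ccoc4c3)nn2)c1`, differs from compound 3 by cyano in place of hydrogen on an aromatic carbon. Two measured steps speak to a group at this ring: an at least 5.6-fold higher number from compound 2 to compound 3 (0.75 log units; beyond the scatter), a clear loss when the group is removed, while an at least 1.4-fold higher number from compound 1 to compound 3 (0.16 log units; that floor lies within the scatter) lies within scatter. Going by these compounds, whether a cyano group behaves like bromo or like methyl is unknown, so a modest downward step is expected, an at least 2.5-fold lower number from compound 3 to compound 4 (0.39 log units; beyond the scatter). Compound 4 is therefore estimated at 40000 nM, between 12000 nM and 130000 nM.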

Compound 4, half-maximal inhibitory concentration: 24400 nM
For compound 4 the middle estimate is 1.6-fold (0.21 log units) above the measured one, and the stated range covers the measured number.
By their numbers in this assay, from the lowest: compounds 2 and 4 (each within the scatter of the next); then compound 1. At a limit, above all of these: compound 3.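

Cyano on this ring carbon, meta to a large group, gives an at least 4.0-fold lower number from compound 3 to compound 4 (0.61 log units; beyond the scatter); this is only a minimum, as the value for compound 3 is a limit of the assay, not a number. Cyano now joins bromo as a group that can occupy this place, and the two cannot be told apart: a 1.4-fold higher number from compound 2 to compound 4 (0.14 log units; within the scatter). Against the 4-methylphenyl group, the 3-cyanophenyl group gives a 2.8-fold lower number from compound 1 to compound 4 (0.45 log units; beyond the scatter), but that step changes both the group and its place on the ring.

Going by these compounds, the effect of place alone remains unknown, as does the effect of cyano at other ring carbons. On these data alone, whether an amine or a carboxylic acid on this same carbon would fare as well also stays open.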